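Dihydropyridine aryloxyacetamides: amide nitrogen substituent and paw edema

The compounds below may be only part of what the source reports. "The series", "measured", "known", "first", "only" and "open" are said of these compounds alone.

Measured compounds:
compound 1 `CCOC(=O)C1=C(C)NC(C)=C(C(=O)OCC)C1c1ccc(OCC(=O)NCc2ccccc2)cc1`, 8.33%
compound 2 `CCOC(=O)C1=C(C)NC(C)=C(C(=O)OCC)C1c1ccc(OCC(=O)Nc2nc3ccccc3s2)cc1`, 47.7%
compound 3 `CCOC(=O)C1=C(C)NC(C)=C(C(=O)OCC)C1c1ccc(OCC(=O)NNC(=O)c2sccc2Cl)cc1`, 10.6%

In a functional assay on the whole organism (strain Wistar) for inhibition, with Rattus norvegicus as the target, read by paw edema, with stated times of 30 min and 0.5 h, at a dose of 20 mg/kg (a lower number here means less inhibition, a higher number more inhibition at the dose given (going by the name of the read-out)), compound 2 stands highest of the three, its steps to compound 3 and to compound 1 both beyond the scatter: a number 39.4 percentage points higher from compound 1 to compound 2 (beyond the scatter) and a number 37.1 percentage points lower from compound 2 to compound 3 (beyond the scatter), while a number 2.3 percentage points higher from compound 1 to compound 3 (within the scatter) stays within it.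

Compound 4 `CCOC(=O)C1=C(C)NC(C)=C(C(=O)OCC)C1c1ccc(OCC(=O)NNC(=O)c2ccsc2Cl)cc1` is still to be measured. It differs from compound 2 in that (a group of 9 heavy atoms (5 carbon, 1 nitrogen, 1 oxygen, 1 sulfur, 1 chlorine; one five-membered aromatic ring with 1 hetero atom) in place of a group of 9 heavy atoms (7 carbon, 1 nitrogen, 1 sulfur; one five-membered aromatic ring with 2 hetero atoms, one six-membered aromatic ring of carbon only), on an amide-type nitrogen). The step that bears most directly on this change is a number 37.1 percentage points lower from compound 2 to compound 3 (beyond the scatter), where a group of the same kind, ((3-chlorothiophen-2-yl)carbonyl)amino, entered on the same amide-type nitrogen and the number fell by a large amount. Compound 4 is therefore expected to show a drop of similar size, a number 35.7 percentage points lower from compound 2 to compound 4 (beyond the scatter), landing near compound 3. The estimate for compound 4 is 12%, between 3% and 25%.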

Compound 4, a percentage reported as inhibition, in the whole organism at one dose (the size of the read-out at that dose, not a potency): 12.9%
Beside the measured number, compound 4's estimate is 0.9 percentage points below it; low and high end bracket the measured number.
By their numbers in this assay, from the lowest: compounds 1, 3 and 4 (each within the scatter of the next); then compound 2.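

In this assay a second chlorothiophene carbonyl group on the amide-type nitrogen repeats the fall, a number 34.8 percentage points lower from compound 2 to compound 4 (beyond the scatter), so this loss is not confined to one thiophene attachment. Exchanging 3-chlorothiophen-2-yl for 2-chlorothiophen-3-yl on the carbonyl carbon gives a number 2.3 percentage points higher from compound 3 to compound 4 (within the scatter), and the comparison with benzyl gives a number 4.6 percentage points higher from compound 1 to compound 4 (within the scatter), leaving compound 2 alone apart from the other three. No evidence here bears on why compound 2 stands apart.

Open, from the compounds shown here alone, is whether the high number needs the whole 1,3-benzothiazol-2-yl group. Thiazol-2-yl or phenyl on the same nitrogen would test this.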